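Lengthening the acyl chain of compound 3

A few compounds are considered here, and "the series" means these few. Any claim that something is new, unique, unknown or untested is made for them only; others in the source may bear on it.

Compound 1 `CCC(=O)NCCCCc1ccc(OC)cc1` and compound 2 `CCCC(=O)NCCCCc1ccc(OC)cc1` share one core; compound 3 `CCC(=O)NCCCc1cccc(F)c1` and compound 4 `CCCC(=O)NCCCc1cccc(F)c1` share another, and the difference between the two cores is not broken down here. In an assay for binding affinity to melatonin receptor (Gallus gallus) (on this read-out lower numbers stand for stronger inhibition and higher numbers for weaker inhibition), compound 1 gives 1400 nM and compound 2 gives 822 nM; the step of a 1.7-fold lower number from compound 1 to compound 2 (0.23 log units; within the scatter) follows the change (methyl in place of hydrogen on a saturated chain carbon, two bonds along the chain from a carbonyl carbon). In this assay compound 3 gives 740 nM, a value lying within the scatter of both compound 1 and compound 2. Compound 4 has not yet been measured. It differs from compound 3 by methyl in place of hydrogen on a saturated chain carbon, two bonds along the chain from a carbonyl carbon, the same change as from compound 1 to compound 2, at the same place, and it occurs twice among these compounds. Compound 4 is expected at 450 nM in this assay, because compound 2 showed a 1.7-fold lower number from compound 1 to compound 2 (0.23 log units; within the scatter) after the same change. The step this estimate means is expected to read a 1.6-fold lower number from compound 3 to compound 4 (0.22 log units; within the scatter), set beside the earlier one. Since that earlier step lay within the scatter, the estimate for compound 4 is expected to span 200 nM to 1000 nM.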

Compound 4, inhibition constant: 434 nM
Beside the measured number, compound 4's estimate is 1.0-fold (0.02 log units) above it; measured number inside the range.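

In this assay the new step reads a 1.7-fold lower number from compound 3 to compound 4 (0.23 log units; within the scatter), and it sits with the earlier step on the other core: the same change on two cores in this assay, a 1.7-fold lower number (0.23 log units; within the scatter) from compound 1 to compound 2 and a 1.7-fold lower number (0.23 log units; within the scatter) from compound 3 to compound 4, 1.0-fold (0.00 log units) apart, within the scatter of two such steps

Within these four compounds, then, methyl in place of hydrogen at this place gave steps of the same size on both cores, and the step read on the first core served as a fair guide to the step on the second. Each step on its own still lies within the scatter, however, so neither one shows that the change truly alters the number, and a single pair of cores says nothing about how the change would carry to any other core.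

The compounds shown carry only the propanoyl and propylcarbonyl groups, which leaves open whether a longer chain, a branched chain or a cyclopropyl group at this place would give a step beyond the scatter. From the compounds shown here alone, whether the same step would hold on a core carrying an amine or a carboxylic acid also stays open.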